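Pyrazine Hydrazones: From Hydroxy to Cyano on the Aryl Ring

The compounds below may be only part of what the source reports. "The series", "measured", "known", "first", "only" and "open" are said of these compounds alone.

Compound 3 `O=C(N/N=C/c1cccc(O)c1)c1cnccn1` was measured in an ADME assay on J774 cells (Mus musculus) for cytotoxicity, read by MTT assay, with a stated time of 48 h, tested at 50 ug/mL (on this read-out higher numbers stand for a weaker effect at the one concentration tested and lower numbers for a stronger effect), where compound 3 gives 100%. This places it level with compound 1 `O=C(N/N=C/c1cccc(Cl)c1)c1cnccn1`, for which compound 1 gives 100%; the two together are the highest of the three numbers, and the step of no change at the digits printed from compound 1 to compound 3 (within the scatter) lies within the scatter. Compound 2 `CCOc1cccc(/C=N/NC(=O)c2cnccn2)c1` stands furthest away: compound 2 gives 74%, and the steps of a number 26 percentage points lower from compound 1 to compound 2 (beyond the scatter) and a number 26 percentage points higher from compound 2 to compound 3 (beyond the scatter) are both beyond the scatter, though modest.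

Compound 4 `N#Cc1cccc(/C=N/NC(=O)c2cnccn2)c1` has not yet been measured. It differs from compound 3 in one place: cyano in place of hydroxy on an aromatic carbon. Within the data shown here, none of the measured steps introduces a cyano group, so no step bears on it directly. What they do show is that exchanging chloro for hydroxy on the aromatic carbon left the number unchanged, while only the ethoxy compound, compound 2, moved it downward.

Given that, compound 4 is expected to stay close to compound 3. The step of a number 6 percentage points lower from compound 3 to compound 4 (within the scatter) is estimated to lie within the scatter or be modest at most. Compound 4 is therefore estimated at 94%, with a range from 72% to 100%.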

Compound 4, a percentage reported as activity, at one concentration (the size of the read-out at that concentration, not a potency): 100%
Compound 4: middle estimate off by 6 percentage points, on the low side; low and high end bracket the measured number.
By their numbers in this assay, from the lowest: compound 2; then compounds 1, 3 and 4 (each within the scatter of the next).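

In this assay, cyano in place of hydroxy on an aromatic carbon gives no change at the digits printed from compound 3 to compound 4 (within the scatter), and cyano in place of chloro gives no change at the digits printed from compound 1 to compound 4 (within the scatter), so a third kind of group joins hydroxy and chloro at this position without shifting the read-out, even though the hydrogen-bond donor of hydroxy is gone. Cyano in place of ethoxy gives a number 26 percentage points higher from compound 2 to compound 4 (beyond the scatter), which leaves ethoxy, in compound 2, as the only one of the four groups that stands apart from the others. No measurement offered here accounts for why ethoxy separates from chloro, hydroxy and cyano.

The compounds shown leave open whether an amine or a carboxylic acid on this aromatic carbon would stay level with chloro, hydroxy and cyano, and whether a longer chain on the oxygen, such as propoxy, would lower the number further than ethoxy does. They also leave open how these groups would behave at another place on the ring, or at any concentration other than the single one tested.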